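This account rests on a few compounds, and the source may have more. Where it says the series, first, only, none or still open, it means among the compounds named here.

Measured so far:
compound 1 `CC(=O)N1N=C(c2ccc(OCc3cn(Cc4ccc([N+](=O)[O-])cc4)nn3)cc2)CC1c1ccccc1` — 0%
compound 2 `COc1ccc(C2CC(c3ccc(OCc4cn(Cc5ccc([N+](=O)[O-])cc5)nn4)cc3)=NN2C(C)=O)cc1` — 15%
compound 3 `COc1cc(C2CC(c3ccccc3)=NN2C(C)=O)ccc1OCc1cn(Cc2ccc([N+](=O)[O-])cc2)nn1` — 0%

In a functional assay on THP-1 cells (Homo sapiens) for inhibition, read by sulforhodamine B assay, tested at 10 uM (a lower number here means less inhibition of growth, a higher number more inhibition of growth at the concentration tested), compound 3 gives 0%, level at the digits printed with compound 1, which gives 0%; together these two stand lowest of the three numbers. Compound 2 gives 15%, a value beyond the scatter above compound 3.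

Compound 4 `COc1cc(C2CC(c3ccc(Cl)cc3)=NN2C(C)=O)ccc1OCc1cn(Cc2ccc([N+](=O)[O-])cc2)nn1` differs from compound 3 in one place: chloro in place of hydrogen on an aromatic carbon, on an aromatic carbon of a six-membered ring of carbon only, para to a large group. For the measured compounds named here, no measured step covers a chloro substituent anywhere. Going by the values given here, the only measured step, a number 15 percentage points higher from compound 1 to compound 2 (beyond the scatter), concerns a methoxy group and is modest, so it gives at best a loose sense of how much a single added group can move this read-out. Starting from the floor at which compound 3 sits, a step within the scatter, or a small rise at most, is expected: a number 5 percentage points higher from compound 3 to compound 4 (within the scatter). Compound 4 is therefore estimated at 5%, with a range from 0% to 20%.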

Compound 4, percent growth inhibition at one concentration: 17%
Beside the measured number, compound 4's estimate is 12 percentage points below it; the measured number falls inside the stated range.
By their numbers in this assay, from the lowest: compounds 1 and 3 (each within the scatter of the next); then compounds 2 and 4 (each within the scatter of the next).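

In this assay, for the compounds shown here, the change from phenyl to 4-chlorophenyl, on an aromatic carbon para to a large group, gives a number 17 percentage points higher from compound 3 to compound 4 (beyond the scatter) and is the first chloro step. It shows that one added chlorine atom at this place is enough to lift a compound out of the zero reading, so a single change on an aromatic carbon can now raise the number with chloro as well as with methoxy, as in a number 15 percentage points higher from compound 1 to compound 2 (beyond the scatter) on a different compound pair. No measured evidence bears on why this change raises the number.

From the compounds shown here alone, whether bromo, fluoro, methyl or an amine at this place would give a comparable number remains open. Also open, going by these compounds, is whether the chloro step would hold on a compound with a different substitution pattern, and how it would appear at concentrations other than the single one tested.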